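A methyl on the amide of compound 3

The source may report more compounds than this note shows. Statements on the series, on what has been measured and on what is new or still open speak of the compounds shown alone.

Measured compounds, each value a limit:
Compound 1 `O=C(NCc1ccccn1)c1ncc([N+](=O)[O-])[nH]1`: > 100000 nM
Compound 2 `O=C(c1ncc([N+](=O)[O-])[nH]1)N1CCCC1`: > 100000 nM
Compound 3 `NC(=O)c1ncc([N+](=O)[O-])[nH]1`: > 100000 nM

In a toxicity assay on HEK293 cells (Homo sapiens) for inhibition, read by resazurin assay, with a stated time of 24 h (on this read-out lower numbers stand for higher toxicity in this test and higher numbers for lower toxicity in this test), compound 3 gives > 100000 nM, which is a limit and not a number. Compound 4 `CNC(=O)c1ncc([N+](=O)[O-])[nH]1` differs from it by methyl in place of hydrogen on an amide-type nitrogen. The nearest measured change is a step that the two limits leave unreadable from compound 2 to compound 3. The wider picture is the limit of > 100000 nM in this assay, at which 3 of the 3 values shown sit. Because a step that the two limits leave unreadable from compound 2 to compound 3 gives no size to carry over, no step beyond the usual scatter is expected in this assay, in either direction. The estimated step is a number no higher from compound 3 to compound 4 (the limit leaves the size open). Compound 4 is expected near 100000 nM, with an estimated range of 50000 nM to 200000 nM, and will most likely be reported only as a limit.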

Compound 4, half-maximal cytotoxic concentration: > 100000 nM
Compound 4: only a limit was reported (the forecaster's own chance of this, stated with the estimate: 85%); the middle value sits exactly at the limit.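

No step can be read between compound 4 and compound 1, compound 2 or compound 3, since each value is only a limit: the limit of > 100000 nM in this assay, at which 4 of the 4 values shown sit. The compounds shown leave open which change, if any, would give a readable toxicity value.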